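Working notes: aryl swap at the five-membered ring, compound 4

The source may report more compounds than this note shows. Statements on the series, on what has been measured and on what is new or still open speak of the compounds shown alone.

Values in a functional assay on U2OS cells for positive allosteric modulation of metabotropic glutamate receptor 5 (Homo sapiens), read by calcium flux, in the presence of a further agent that is not named here (a lower number here means that less compound is needed, a higher number that more compound is needed for the effect), so far:
compound 1 `Fc1ccc(-c2noc(C3CCc4c(nnn4-c4ccc(F)nc4)C3)n2)cc1`: > 25100 nM (a limit)
compound 2 `CC(C)n1nnc2c1CCC(c1nc(-c3ccc(F)cc3)no1)C2`: 398 nM
compound 3 `Cc1ccc(-c2noc(C3CCc4c(nnn4C(C)(C)C)C3)n2)cn1`: 1580 nM

Compound 1 reports only a limit, (the limit of > 25100 nM in this assay, at which 1 of the 3 values shown sits). Of the two real numbers, compound 3 holds the higher one and compound 2 the lower one. For the measured compounds named here, the single measured step, an at least 63-fold lower number from compound 1 to compound 2 (1.79 log units; beyond the scatter), concerns the group on the aromatic nitrogen and not the aryl group carried by the five-membered ring.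

Compound 4 `CN(C)c1ccc(-c2noc(C3CCc4c(nnn4C(C)(C)C)C3)n2)cc1` differs from compound 3 by 4-(dimethylamino)phenyl in place of 6-methylpyridin-3-yl on an aromatic carbon. Going by the values given here, no measured step touches this position, so no direction can be read from the data. In this assay compound 4 is expected near compound 3, at about 1300 nM with a range of 350 nM to 5000 nM. The expected step of a 1.2-fold lower number from compound 3 to compound 4 (0.08 log units; within the scatter) is estimated to stay within the usual scatter.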

Compound 4, half-maximal effective concentration: 1000 nM
The estimate for compound 4 lay 1.3-fold (0.11 log units) above the measured number; the measured number falls inside the stated range.
By their numbers in this assay, from the lowest: compound 2; then compounds 4 and 3 (each within the scatter of the next). At a limit, above all of these: compound 1.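

This position on the five-membered ring now has its first measured step: 4-(dimethylamino)phenyl in place of 6-methylpyridin-3-yl gives a 1.6-fold lower number from compound 3 to compound 4 (0.20 log units; within the scatter) in this assay. A six-membered aromatic ring of carbon only and one with a hetero atom therefore read alike here, with the shared core and the group on the aromatic nitrogen unchanged. Nothing measured here gives a reason for this result.

As far as these compounds go, whether a carboxylic acid or a saturated ring would read the same at this position stays open. So does whether this aryl swap reads alike with isopropyl on the aromatic nitrogen, the group of compound 2.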